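The source may hold more compounds than are shown below. What is called first, only, known or untested is meant among the compounds shown, and "the series" means these compounds.

Compound 1 `Cc1cc(Cl)ccc1C(=O)Nc1ccc(Cl)c(-c2nnc3c(Cl)cccn23)c1` sits at the assay limit in a functional assay on A549 cells (Homo sapiens) for antiproliferative activity, read by MTT assay, with a stated time of 72 h (a higher number here means a weaker inhibitor, a lower number a stronger inhibitor), where compound 1 gives > 100000 nM. Going by the values given here, compound 2 `O=C(Nc1ccc(Cl)c(-c2nnc3c(Cl)cccn23)c1)c1ccon1` supplies the only actual number of the pair, giving 42700 nM in this assay. Among the compounds with values here, the single measured step, an at least 2.3-fold lower number from compound 1 to compound 2 (0.36 log units; beyond the scatter), swapped a carbon-only aromatic ring for the five-membered heteroaromatic one. Compound 3 `O=C(Nc1ccc(Cl)c(-c2nnc3c(Cl)cccn23)c1)c1ccccc1Cl` differs from compound 2 by 2-chlorophenyl in place of 1,2-oxazol-3-yl on a carbonyl carbon, which runs that change backwards. Since that exchange gave an at least 2.3-fold lower number from compound 1 to compound 2 (0.36 log units; beyond the scatter), a step of similar size toward higher numbers is expected, roughly a 2.1-fold higher number from compound 2 to compound 3 (0.32 log units; beyond the scatter). Compound 3 is therefore estimated at 90000 nM, with a range from 30000 nM to 300000 nM, and a fair chance that this assay again reports only a limit.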

Compound 3, half-maximal inhibitory concentration: > 100000 nM
Compound 3: no number, only a limit; the forecaster's own chance of this, stated with the estimate: 45%; at least 1.1-fold (0.04 log units) between middle value and limit.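

With 1,2-oxazol-3-yl on the carbonyl carbon now set against two different carbon-only aromatic rings, this assay gives an at least 2.3-fold higher number from compound 2 to compound 3 (0.36 log units; beyond the scatter). The lower number of compound 2 therefore does not rest on comparison with the 4-chloro-2-methylphenyl group of compound 1 alone, since 2-chlorophenyl goes the same way. The step from compound 1 to compound 3 cannot be read, as both values are limits: the limit of > 100000 nM in this assay, at which 2 of the 3 values shown sit.

The compounds shown leave open how a pyridin-2-yl or a furan-2-yl group on that carbonyl carbon would read. Whether the hetero atoms or the ring size goes with the lower number of compound 2 therefore remains unsettled.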